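This account rests on a few compounds, and the source may have more. Where it says the series, first, only, none or still open, it means among the compounds named here.

Three compounds share one core and differ only in the aromatic group attached to the sulfonyl sulfur of the sulfonamide. Compound 1 `COc1cc(N)c(Cl)cc1C(=O)CCC1CCN(CCNS(=O)(=O)c2cc(Br)ccc2Br)CC1` carries a dibromophenyl group, and in an assay on HEK293 cells for displacement of a labelled ligand from 5-hydroxytryptamine receptor 6 (Homo sapiens), with a stated time of 60 min, tested at 0.01 uM, in the presence of a further agent that is not named here (on this read-out higher numbers stand for a stronger effect at the one concentration tested and lower numbers for a weaker effect), compound 1 gives 16%. Compound 2 `COc1ccc(S(=O)(=O)NCCN2CCC(CCC(=O)c3cc(Cl)c(N)cc3OC)CC2)cc1Br` carries a 3-bromo-4-methoxyphenyl group, and in this assay compound 2 is reported as "not active" (no number reported), a verdict without any number attached, so compound 2 cannot be placed on the scale with a figure of its own; it stands simply as a compound for which no measurable effect was recorded.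

Compound 3 `COc1cc(N)c(Cl)cc1C(=O)CCC1CCN(CCNS(=O)(=O)c2ccc(C)cc2)CC1` is the next member. The change from compound 2 to compound 3 is 4-methylphenyl in place of 3-bromo-4-methoxyphenyl on a sulfonyl sulfur. Among the compounds with values here, no measured step between neighbouring compounds is available to guide the size of the move in this assay; with compound 1 at 16% and compound 2 at "not active" (no number reported), both weak, the expectation is for no move beyond the scatter, staying in the weak range. Compound 3 is therefore estimated at 10%, with a likely range from 0% to 28%.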

Compound 3, a percentage reported as inhibition, at one concentration (the size of the read-out at that concentration, not a potency): "not active" (no number reported)
Nothing numeric was reported for compound 3; no gap can be computed for the estimate.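

Compound 2 and compound 3 carry no number in this assay, and no step can be read between them. No measurement at hand offers an explanation for this result. The compounds shown leave open whether changing the aromatic group on the sulfonyl sulfur can produce a clear effect.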